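From Phenyl to Naphthalen-1-yl: Estimating One More Step

The source may report more compounds than this note shows. Statements on the series, on what has been measured and on what is new or still open speak of the compounds shown alone.

Of the compounds shown here, two have been measured so far in a functional assay on THP-1 cells (Homo sapiens) for inhibition, read by sulforhodamine B assay, with a stated time of 48 h, tested at 50 uM; a lower number here means less inhibition of growth, a higher number more inhibition of growth at the concentration tested. Compound 1 `COc1cccc(/C=C/C(=O)/C=C/c2ccc(OCc3cn(CCCCOc4cc(=O)oc5ccccc45)nn3)c(OC)c2)c1` gives 47%. Compound 2 `COc1cc(/C=C/C(=O)/C=C/c2ccccc2)ccc1OCc1cn(CCCCOc2cc(=O)oc3ccccc23)nn1` gives 36%, the lower of the two numbers.

The next compound, compound 3 `COc1cc(/C=C/C(=O)/C=C/c2cccc3ccccc23)ccc1OCc1cn(CCCCOc2cc(=O)oc3ccccc23)nn1`, keeps the shared core of compound 2 and changes a single group: naphthalen-1-yl in place of phenyl on a double-bonded chain carbon bound to a double-bonded chain carbon. The swap sits on a double-bonded chain carbon bound to a double-bonded chain carbon.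

For the measured compounds named here, only one measured step bears on this change: a number 11 percentage points lower from compound 1 to compound 2 (beyond the scatter). There, hydrogen takes the place of methoxy on an aromatic carbon, within the same phenyl group that compound 3 replaces. Removing that methoxy gave a modest drop, so a larger group at this end may give a modest rise. A single step is thin support, however, and it says nothing directly about naphthalen-1-yl. The expected change in this assay is therefore small and upward, estimated as a number 7 percentage points higher from compound 2 to compound 3 (within the scatter). For compound 3 the estimated value is 43%, with an expected range of 28% to 58%.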

Compound 3, percent growth inhibition at one concentration: 54%
Estimate against measurement, compound 3: 11 percentage points below, within the range that was stated.
By their numbers in this assay, from the lowest: compound 2; then compounds 1 and 3 (each within the scatter of the next).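

In this assay, putting naphthalen-1-yl in place of phenyl on a double-bonded chain carbon bound to a double-bonded chain carbon gives a number 18 percentage points higher from compound 2 to compound 3 (beyond the scatter), so this end of the molecule can carry a second aromatic ring of carbon without a loss of growth inhibition. Naphthalen-1-yl and 3-methoxyphenyl cannot be told apart at this place, since the swap between them gives a number 7 percentage points higher from compound 1 to compound 3 (within the scatter), and both groups stand above plain phenyl by more than the scatter. No evidence is available on what lies behind these differences.

On these data alone, it remains open whether naphthalen-2-yl would read like naphthalen-1-yl here, and whether a phenyl group carrying an amine or a carboxylic acid would keep the number or lower it. As far as these compounds go, since this assay reports growth inhibition at one concentration only, it also remains open how these compounds would compare across a range of concentrations.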